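This account rests on a few compounds, and the source may have more. Where it says the series, first, only, none or still open, it means among the compounds named here.

Among the measured compounds shown here, compound 1 `CCSc1ccc2c(c1)c(O)c(C(=O)N(C)c1ccccc1)c(=O)n2C` gives 100% in a functional assay on the whole organism for inhibition, with Mus musculus as the target, at a dose of 32 mg/kg by the oral route (on this read-out lower numbers stand for less inhibition and higher numbers for more inhibition at the one dose given (going by the name of the read-out)), the highest of the three numbers measured so far. Compound 2 `COCn1c(=O)c(C(=O)N(C)c2ccccc2)c(O)c2cc(SC)ccc21` gives 78% in this assay, and compound 3 `CSc1ccc2c(c1)c(O)c(S(=O)(=O)N(C)c1ccccc1)c(=O)n2C` gives 53% in this assay; both stand lower than compound 1 by more than the usual scatter of repeated measurements. Compound 4 `CN(C(=O)c1c(O)c2cc(S(C)(=O)=O)ccc2n(C)c1=O)c1ccccc1` has not yet been measured. It differs from compound 1 in a single place: methylsulfonyl in place of ethylsulfanyl on an aromatic carbon. For the measured compounds named here, no measured pair of compounds shows this same change, so its effect is not known from the data. Because compound 1 already gives 100%, the number for compound 4 can only hold or fall. The step of a number 35 percentage points lower from compound 1 to compound 4 (beyond the scatter) is expected to be a moderate drop, beyond the scatter. Compound 4 is estimated at 65%, with a range from 30% to 95%.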

Compound 4, a percentage reported as inhibition, in the whole organism at one dose (the size of the read-out at that dose, not a potency): 0%
The estimate for compound 4 lay 65 percentage points above the measured number; measured number below the stated range.
By their numbers in this assay, from the lowest: compound 4; then compound 3; then compound 2; then compound 1.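

Swapping ethylsulfanyl for methylsulfonyl on this aromatic carbon of the shared core gives a number 100 percentage points lower from compound 1 to compound 4 (beyond the scatter) in this assay. This single change is enough to separate the top number from the bottom one, so the group at this position matters greatly to the result. Nothing measured here explains the drop.

From the compounds shown here alone, the step changes the chain and adds two oxygens on sulfur at once, so their separate shares remain open. Going by these compounds, how ethylsulfonyl or a simple amine at this position would read out also remains open.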